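A few compounds are considered here, and "the series" means these few. Any claim that something is new, unique, unknown or untested is made for them only; others in the source may bear on it.

Compound 1 `N#Cc1ccc(Nc2nccc(Oc3ccc(-c4ccc(C#N)c(Cl)c4)cc3Cl)n2)cc1` and compound 3 `N#Cc1ccc(Nc2nccc(Oc3ccc(-c4ccc(C#N)cc4Cl)cc3Cl)n2)cc1` share one core and differ in a single place. In a functional assay on MT4 cells (Homo sapiens) for cytotoxicity, read by MTT assay, with a stated time of 5 days (on this read-out lower numbers stand for higher toxicity in this test and higher numbers for lower toxicity in this test), compound 1 gives 14900 nM. For compound 3 the measurement reached only a limit of the assay, > 273000 nM, at the limit of > 273000 nM in this assay, at which 1 of the 3 values shown sits. Between them stands an at least 18-fold higher number from compound 1 to compound 3 (1.26 log units; beyond the scatter). Compound 2 `COc1cc(Oc2ccnc(Nc3ccc(C#N)cc3)n2)ccc1-c1ccc(C#N)cc1` likewise gave only a limit in this assay, > 298000 nM, so no number is known for it. Compound 2 sits at the limit of > 298000 nM in this assay, at which 1 of the 3 values shown sits. Compound 4 `N#Cc1ccc(Nc2nccc(Oc3ccc(-c4ccc(C#N)cc4)c(F)c3)n2)cc1` differs from compound 2 by fluoro in place of methoxy on an aromatic carbon. Going by the values given here, the one measured step moves a chloro on a different ring and so does not bear directly on this change. Compound 4 is expected to give an at least 1.4-fold lower number from compound 2 to compound 4 (0.17 log units; that floor lies within the scatter). Compound 4 is estimated at 200000 nM, within 50000 nM to 300000 nM.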

Compound 4, half-maximal cytotoxic concentration: > 307000 nM
Compound 4 ended at the assay's limit (the forecaster's own chance of this, stated with the estimate: 60%); at least 1.5-fold (0.18 log units) between middle value and limit.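

Compound 2 and compound 4 both ended at limits of this assay, so the step from methoxy to fluoro cannot be read. The compounds shown leave open what actual number either compound would give.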